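This account rests on a few compounds, and the source may have more. Where it says the series, first, only, none or still open, it means among the compounds named here.

Measured compounds:
- compound 1 `C[C@@H]1CN(C2CCN(Cc3ccc(Cl)cc3)CC2)CCN1c1ncc(C(=O)NCc2ccc(Cl)c(Cl)c2)cc1Cl`: in a functional assay for antagonist activity at C-X-C chemokine receptor type 3 (Homo sapiens) (on this read-out lower numbers stand for stronger inhibition and higher numbers for weaker inhibition), compound 1 gives 220 nM
- compound 2 `CCNC(=N)c1cnc(N2CCN(C3CCN(Cc4ccc(Cl)cc4)CC3)[C@@H](C)C2)c(Cl)c1`: in this assay compound 2 gives 83 nM

Of the two measured compounds, compound 2 stands at the lower number, and its gap to compound 1 is beyond the usual scatter; the two structures differ in several places at once, so nothing more than the two values themselves can be read from that pair.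

Compound 3 `CC(C)NC(=O)c1cnc(N2CCN(C3CCN(Cc4ccc(Cl)cc4)CC3)[C@@H](C)C2)c(Cl)c1` is the unmeasured compound. It differs from compound 2 in one place: a group of 6 heavy atoms (4 carbon, 1 nitrogen, 1 oxygen; no ring) in place of a group of 5 heavy atoms (3 carbon, 2 nitrogen; no ring), on an aromatic carbon, that is, an isopropylcarbamoyl in place of the earlier group, two atoms from the ring nitrogen, meta to a chloro group and para to a large group.

For the measured compounds named here, no step of this kind has been measured within this set, so the expectation rests on the structural change alone. The step from compound 2 to compound 3 is expected to be a moderate rise in the number, a 3.0-fold higher number from compound 2 to compound 3 (0.48 log units; beyond the scatter), somewhat beyond the scatter. Compound 3 is accordingly estimated at 250 nM, with a range from 80 nM to 800 nM.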

Compound 3, half-maximal inhibitory concentration: 5 nM
Beside the measured number, compound 3's estimate is 50-fold (1.70 log units) above it; measured number below the stated range.
By their numbers in this assay, from the lowest: compound 3; then compound 2; then compound 1.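

In this assay, replacing the group of 5 heavy atoms (3 carbon, 2 nitrogen) with an isopropylcarbamoyl, on the aromatic carbon two atoms from the ring nitrogen, gives a 17-fold lower number from compound 2 to compound 3 (1.22 log units; beyond the scatter). For the compounds shown here, this is the first comparison in the set that changes only one place, and it shows that inhibition depends strongly on the group at this position, even though the two groups are close in size, neither has a ring, and each has 1 double bond outside aromatic rings and 1 hydrogen-bond acceptor, while the isopropylcarbamoyl has 1 hydrogen-bond donor against 2 in the group it replaces. No measurement at hand accounts for the size of this step.

The two groups differ in several features at once, so the compounds shown leave open whether the gain belongs to the carbonyl oxygen, to the isopropyl or to both together. Also open, on these data alone, is how an ethylcarbamoyl, a cyclopropylcarbamoyl, a tert-butylcarbamoyl or a carboxylic acid at the same position would compare with the isopropylcarbamoyl.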